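This account rests on a few compounds, and the source may have more. Where it says the series, first, only, none or still open, it means among the compounds named here.

Measured so far in a functional assay on HCT-116 cells (Homo sapiens) for inhibition, read by MTT assay, with a stated time of 48 h; a lower number here means a stronger inhibitor, a higher number a weaker inhibitor:
- compound 1 `COc1cc(-c2nccn3cc(-c4ccc(Cl)cc4)nc23)cc(OC)c1OC` gives 351 nM
- compound 2 `COc1cc(-c2nccn3cc(-c4ccc5[nH]ccc5c4)nc23)cc(OC)c1OC` gives 23 nM

Compound 2, at 23 nM, holds the lower of the two numbers, and the gap to compound 1 is beyond the scatter. The next compound to be read is compound 3 `COc1cc(-c2nccn3cc(-c4ccccc4)nc23)cc(OC)c1OC`, which carries phenyl in place of 1H-indol-5-yl on an aromatic carbon.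

For the measured compounds named here, only one measured step bears on this change. It is a 15-fold lower number from compound 1 to compound 2 (1.18 log units; beyond the scatter), a large step beyond the scatter, with 1H-indol-5-yl replacing 4-chlorophenyl at the same place. Compound 3 loses that 1H-indol-5-yl and, like compound 1, has a single six-membered aromatic ring of carbon only there, differing from compound 1 by the missing chloro substituent. Going by the values given here, no measurement yet shows what that substituent contributes, so this comparison remains uncertain.

A large rise of similar size is therefore expected, beyond the scatter: the estimated change is a 15-fold higher number from compound 2 to compound 3 (1.18 log units; beyond the scatter) in this assay. The estimate for compound 3 is 350 nM, with an expected range from 110 nM to 1100 nM.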

Compound 3, half-maximal inhibitory concentration: 266 nM
Compound 3: middle estimate off by 1.3-fold (0.12 log units), on the high side, within the range that was stated.
By their numbers in this assay, from the lowest: compound 2; then compounds 3 and 1 (each within the scatter of the next).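

In this assay, the step of a 12-fold higher number from compound 2 to compound 3 (1.06 log units; beyond the scatter) shows that with phenyl in place of 1H-indol-5-yl on this aromatic carbon, the low number of compound 2 is lost against the unsubstituted ring as well, not only against 4-chlorophenyl. The step of a 1.3-fold lower number from compound 1 to compound 3 (0.12 log units; within the scatter), with hydrogen in place of chloro, stays within the scatter, so the chloro substituent makes no readable difference here and the gap to compound 2 does not rest on it. No measured evidence explains the gap at this position.

The change from phenyl to 1H-indol-5-yl adds a five-membered aromatic ring and a hydrogen-bond donor together, and compounds 1, 2 and 3 cannot tell these two apart. A 1-methyl-1H-indol-5-yl group, which keeps both rings but replaces the ring hydrogen on nitrogen, or a naphthalen-2-yl group, with two fused carbon rings, would separate them, while a 4-aminophenyl group would test whether a single six-membered ring can carry a donor at this place with the same result.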